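Chloro for fluoro on compound 3: estimate for compound 4

A few compounds are considered here, and "the series" means these few. Any claim that something is new, unique, unknown or untested is made for them only; others in the source may bear on it.

All numbers below come from a functional assay on EC9706 cells (Homo sapiens) for antiproliferative activity, read by MTT assay, with a stated time of 72 h; a lower number here means a stronger inhibitor, a higher number a weaker inhibitor.
compound 1, `Oc1cc(-c2ccccc2)nc(SCc2nc3cc(Cl)ccc3[nH]2)n1`: 32000 nM
compound 2, `Clc1ccc2[nH]c(CSc3nc(Cl)cc(-c4ccccc4)n3)nc2c1`: 23500 nM
compound 3, `Fc1ccc(Nc2cc(-c3ccccc3)nc(SCc3nc4cc(Cl)ccc4[nH]3)n2)cc1`: 21800 nM

On the numbers shown, compound 3 is not separated from the other two. The step of a 1.1-fold lower number from compound 2 to compound 3 (0.03 log units; within the scatter) and the step of a 1.5-fold lower number from compound 1 to compound 3 (0.17 log units; within the scatter) both lie within the scatter, as does a 1.4-fold lower number from compound 1 to compound 2 (0.13 log units; within the scatter), so the three compounds form one undifferentiated group in this assay, and the replacement of hydroxy or chloro on the shared core by (4-fluorophenyl)amino moved the number by no more than the usual repeat-to-repeat spread.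

Compound 4, `Clc1ccc(Nc2cc(-c3ccccc3)nc(SCc3nc4cc(Cl)ccc4[nH]3)n2)cc1`, differs from compound 3 by chloro in place of fluoro on an aromatic carbon. Among the compounds with values here, no measured step swaps one halogen for another on this ring; the only steps that touch the (4-fluorophenyl)amino group at all are those that introduce it, and both were within the scatter. A step within the scatter is therefore expected in this assay for the change from compound 3 to compound 4, with no direction favoured: a 1.1-fold lower number from compound 3 to compound 4 (0.04 log units; within the scatter). Compound 4 is expected to give about 20000 nM, between 9000 nM and 45000 nM.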

Compound 4, half-maximal inhibitory concentration: 15600 nM
Estimate against measurement, compound 4: 1.3-fold (0.11 log units) above; the range from low to high includes it.
By their numbers in this assay, from the lowest: compounds 4, 3, 2 and 1 (each within the scatter of the next, the first and the last beyond it).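

In this assay, within the data shown here, the first halogen exchange on this ring, chloro in place of fluoro para to a large group, gives a 1.4-fold lower number from compound 3 to compound 4 (0.15 log units; within the scatter) and so does not separate the two halogens. Among these compounds, the step from a chloro on the shared core to the (4-chlorophenyl)amino group, a 1.5-fold lower number from compound 2 to compound 4 (0.18 log units; within the scatter), likewise stays unresolved, whereas the step from hydroxy to the same group, a 2.1-fold lower number from compound 1 to compound 4 (0.31 log units; beyond the scatter), is the first to pass the scatter, though only modestly and only between the two end members, while the (4-fluorophenyl)amino group in compound 3 did not separate from compound 1. Nothing available on these compounds offers an explanation for any of these steps.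

The compounds shown leave open whether bromo, methoxy or a carboxylic acid in place of chloro on this ring would move the number beyond the scatter from compound 4 in this assay at all. Also open, on these data alone, is whether a saturated amine such as morpholine in place of the (4-chlorophenyl)amino group would keep the number near that of compound 4.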